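A few compounds are considered here, and "the series" means these few. Any claim that something is new, unique, unknown or untested is made for them only; others in the source may bear on it.

Working notes on the hydroxyphenyl-pyridine series

Compound 1 `Oc1ccccc1-c1cc(-c2ccccc2C(F)(F)F)cc(-c2ccccc2O)n1` gives 4770 nM in a functional assay on DU-145 cells (Homo sapiens) for inhibition; a higher number here means a weaker inhibitor, a lower number a stronger inhibitor. Compound 3 `Oc1ccccc1-c1cc(-c2ccccc2OC(F)(F)F)cc(-c2ccccc2O)n1` carries the change trifluoromethoxy in place of trifluoromethyl on an aromatic carbon and gives 5850 nM in this assay; the step of a 1.2-fold higher number from compound 1 to compound 3 (0.09 log units; within the scatter) keeps the two compounds within the scatter of each other.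

Compound 2 `Oc1ccccc1-c1cc(-c2cccc(C(F)(F)F)c2)cc(-c2ccccc2O)n1` differs from compound 1 in its core by 3-(trifluoromethyl)phenyl in place of 2-(trifluoromethyl)phenyl on an aromatic carbon. For compound 2 only a limit of the assay, not a number, is reported: in this assay compound 2 sits at > 50000 nM (the limit of > 50000 nM in this assay, at which 1 of the 3 values shown sits). The step of an at least 10-fold higher number from compound 1 to compound 2 (1.02 log units; beyond the scatter) is therefore a lower bound on the loss.

Compound 4 `Oc1ccccc1-c1cc(-c2cccc(OC(F)(F)F)c2)cc(-c2ccccc2O)n1` awaits measurement in this assay. It differs from compound 2 by trifluoromethoxy in place of trifluoromethyl on an aromatic carbon, the same kind of change as that from compound 1 to compound 3, though here the group stands meta to a large group rather than ortho to a large group. The expected step that the limit leaves unreadable from compound 2 to compound 4 rests on a 1.2-fold higher number from compound 1 to compound 3 (0.09 log units; within the scatter), which lies within the scatter, so no real shift is anticipated from a limit value. Compound 4 is estimated at 70000 nM, within 30000 nM to 200000 nM, most likely reported as a limit again.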

Compound 4, half-maximal inhibitory concentration: 7470 nM
The estimate for compound 4 lay 9.4-fold (0.97 log units) above the measured number, and the stated range ends above it.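

In this assay the new step is an at least 6.6-fold lower number from compound 2 to compound 4 (0.82 log units; beyond the scatter), so trifluoromethoxy in place of trifluoromethyl does not carry over from the core of compound 1 to the core of compound 2 as a fixed shift: the same change on two cores in this assay, a 1.2-fold higher number (0.09 log units; within the scatter) from compound 1 to compound 3 and an at least 6.6-fold lower number (0.82 log units; beyond the scatter) from compound 2 to compound 4, at least 8.2-fold (0.91 log units) apart, beyond the scatter of two such steps

Compound 2 has only a limit of the assay, not a number: the limit of > 50000 nM in this assay, at which 1 of the 4 values shown sits.

The true size of the step and of the gap between the two steps therefore stays unknown, and two pairs show only that the outcome of this change differed between these two cores, not a rule for any other core, nor any reason for the difference.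

The compounds shown leave open whether a similar step would appear with a methoxy group or a chlorine atom in place of trifluoromethyl on the same aromatic carbon. They also leave open how a change on the shared core itself, such as a methoxy group in place of either hydroxy group, would read in this assay.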